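The compounds below may be only part of what the source reports. "The series", "measured", "known", "first", "only" and "open" are said of these compounds alone.

Of the compounds shown here, two have so far been measured in a physicochemical assay for lipophilicity, measured as octanol-water partition, at pH 7.4; on this read-out higher numbers stand for higher lipophilicity and lower numbers for lower lipophilicity. Compound 1 (`CC(C)c1noc(N2CCC(Oc3cc(N4CCc5cc(N6CCCS6(=O)=O)ccc54)ncn3)CC2)n1`) gives 3.2 and is the lower of the two. Compound 2 (`CC(C)SC(=O)N1CCC(Oc2cc(N3CCc4cc(S(C)(=O)=O)ccc43)ncn2)CC1`) gives 3.6 on the same scale, a gap beyond the usual scatter of the method. These two differ in more than one place, so their gap cannot be tied to any single change.

Compound 3 (`CC(C)c1noc(N2CCC(Oc3cc(N4CCc5cc(N6CCC(O)CC6=O)ccc54)ncn3)CC2)n1`) has not yet been measured. It keeps the core of compound 1 and exchanges one group on an aromatic carbon: a group of 8 heavy atoms (5 carbon, 1 nitrogen, 2 oxygen; one six-membered non-aromatic ring with 1 hetero atom) in place of a group of 7 heavy atoms (3 carbon, 1 nitrogen, 2 oxygen, 1 sulfur; one five-membered non-aromatic ring with 2 hetero atoms), on an aromatic carbon. For the measured compounds named here, the entering group is 4-hydroxy-2-oxopiperidin-1-yl, whose hydrogen-bond donor has no counterpart in the group that leaves. Going by the values given here, no measured pair shows this exchange, so the expectation rests on that structural difference alone, with compound 1 at 3.2 as the starting point. A modest fall is expected, with an estimated a number 0.50 log units lower from compound 1 to compound 3 (beyond the scatter) as the size of the step. For compound 3 the expected value is 2.7, with an estimated range from 2.2 to 3.2.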

Compound 3, distribution coefficient: 2.8
Compound 3: the middle estimate sits 0.10 log units below what was measured; measured number inside the range.
By their numbers in this assay, from the lowest: compound 3; then compound 1; then compound 2.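

With the core of compound 1 held fixed, a shift in this assay can now be tied to a single place, an aromatic carbon of the fused system: putting 4-hydroxy-2-oxopiperidin-1-yl there gives a number 0.40 log units lower from compound 1 to compound 3 (beyond the scatter). This exchange changes several things at once, since the entering group carries a hydrogen-bond donor that the leaving group lacks, has a six-membered rather than a five-membered ring, and contains no sulfur, so this one step shows the combined outcome and does not divide it among those features. Nothing measured here bears on the reason for the fall.

The compounds shown leave open how much of the step belongs to the hydroxy group and how much to the rest of the ring, a question that a plain 2-oxopiperidin-1-yl group on the same carbon would help to settle. They also leave open how an amine or a carboxylic acid at this place would compare, and whether the same exchange would give a similar step on a different core.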